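Varying the aryl amide in a weakly antiproliferative series

The source may hold more compounds than are shown below. What is called first, only, known or untested is meant among the compounds shown, and "the series" means these compounds.

Compound 1 `O=C(Nc1ccc(Cl)c(-c2nnc3c(Cl)cccn23)c1)c1ccccc1` is the reference point here: in a functional assay on AN3-CA cells (Homo sapiens) for antiproliferative activity, read by MTT assay, with a stated time of 72 h (on this read-out lower numbers stand for stronger inhibition and higher numbers for weaker inhibition), compound 1 gives 67600 nM. Compound 2 `O=C(Nc1ccc(Cl)c(-c2nnc3c(Cl)cccn23)c1)c1ccccc1Cl` adds chloro in place of hydrogen on an aromatic carbon, and in this assay compound 2 reaches only the limit > 100000 nM. Compound 3 `Cc1cc(Cl)ccc1C(=O)Nc1ccc(Cl)c(-c2nnc3c(Cl)cccn23)c1` carries 4-chloro-2-methylphenyl in place of phenyl on the carbonyl carbon, and in this assay compound 3 likewise gives only the limit > 100000 nM. The measured steps are an at least 1.4-fold higher number from compound 1 to compound 2 (0.17 log units; that floor lies within the scatter) and an at least 1.4-fold higher number from compound 1 to compound 3 (0.17 log units; that floor lies within the scatter), while the step that the two limits leave unreadable from compound 2 to compound 3 cannot be sized, since (the limit of > 100000 nM in this assay, at which 2 of the 3 values shown sit). Compound 3 therefore stands at that limit, not at a number.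

Compound 4 `O=C(Nc1ccc(Cl)c(-c2nnc3c(Cl)cccn23)c1)c1ccc(F)cc1Cl` differs from compound 3 only on the carbonyl carbon: 2-chloro-4-fluorophenyl in place of 4-chloro-2-methylphenyl on a carbonyl carbon. The two steps that change this same aryl group, from compound 1 and between the two limit compounds, show no readable movement, so compound 4 is expected to stay near the limit, with the step that the limit leaves unreadable from compound 3 to compound 4 expected to be none beyond the scatter. Compound 4 is estimated at 150000 nM, in the range 50000 nM to 500000 nM.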

Compound 4, half-maximal inhibitory concentration: > 100000 nM
Compound 4: no number, only a limit; the forecaster's own chance of this, stated with the estimate: 75%; the middle value does not contradict the limit.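

With 2-chloro-4-fluorophenyl on the carbonyl carbon, a fluoro-bearing aryl group joins the comparison with the phenyl of compound 1, and the change gives an at least 1.4-fold higher number from compound 1 to compound 4 (0.17 log units; that floor lies within the scatter). The steps to compound 4 from compound 2 and from compound 3 cannot be read, as both ends of each are limits, so neither adding fluoro nor replacing 4-chloro-2-methylphenyl has a measurable size here. Three different substituted aryl groups now end at the same limit, with compound 1 the only one of the four to give a number: the limit of > 100000 nM in this assay, at which 3 of the 4 values shown sit.

On these data alone, it remains open how an amine or a carboxylic acid on this aryl group, or a longer chain in its place, would read in this assay. As far as these compounds go, the true distance of the three limit compounds from compound 1, or from one another, also remains open.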